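Two Chlorines Replace a Vinyl Group on the Amide

The source may hold more compounds than are shown below. What is called first, only, known or untested is meant among the compounds shown, and "the series" means these compounds.

Measured compounds:
Compound 1, `Cc1cccc(NC(=O)CN2CCC(c3cccc(O)c3)CC2)c1`, gives 66%
Compound 2, `C=Cc1cccc(C(=O)NCN2CCC(c3cccc[n+]3[O-])CC2)c1`, gives 63%
Compound 3, `Cc1ccc([N+](=O)[O-])cc1NC(=O)CN1CCC(c2cccc[n+]2[O-])CC1`, gives 76%

All three were tested in a functional assay on HEK293 cells for agonist activity at D(4) dopamine receptor (Homo sapiens), read by FLIPR; a higher number here means a larger maximal response, a lower number a smaller maximal response. Compound 2, with 63%, cannot be separated from compound 1, whose 66% lies within the scatter of it. Compound 3, with 76%, stands above compound 2 by a gap that goes beyond the scatter.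

Compound 4, `O=C(NCN1CCC(c2cccc[n+]2[O-])CC1)c1cc(Cl)cc(Cl)c1`, has not yet been measured. It differs from compound 2 in one place: 3,5-dichlorophenyl in place of 3-vinylphenyl on a carbonyl carbon. Among the measured compounds, no pair differs by exactly this change, and the three of them differ from each other in several places at once, so there is no measured step to lean on. Since the two groups are of the same size and carry the same count of donors and acceptors, the step of a number 2 percentage points higher from compound 2 to compound 4 (within the scatter) is expected to stay within the scatter. Compound 4 is estimated at 65%, with a range from 50% to 80%.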

Compound 4, largest response reached (reported as efficacy), in percent of the reference or control that the assay uses: 64%
For compound 4 the middle estimate is 1 percentage points above the measured one; measured number inside the range.
By their numbers in this assay, from the lowest: compounds 2, 4, 1 and 3 (each within the scatter of the next, the first and the last beyond it).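

Within the data shown here, on the carbonyl carbon, 3,5-dichlorophenyl in place of 3-vinylphenyl gives a number 1 percentage points higher from compound 2 to compound 4 (within the scatter) in this assay and offers the first comparison here between compounds that differ in only one place. The two groups have the same number of heavy atoms and the same aromatic ring of carbon only, yet two chlorine atoms enter and a double bond outside the ring leaves without a response that can be told apart at this position. Nothing measured here explains this match.

One exchange cannot show whether a different kind of group on the phenyl ring, such as an amine or a carboxylic acid, would also leave the maximal response within the scatter. It also leaves open whether the same exchange would give a step this small on a different core.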